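Swapping cyclopropyl for phenyl on the amine side chain

The source may report more compounds than this note shows. Statements on the series, on what has been measured and on what is new or still open speak of the compounds shown alone.

Measured compounds in a functional assay on aorta for inhibition of Voltage-dependent L-type calcium channel subunit alpha-1C (Rattus norvegicus); a higher number here means a weaker inhibitor, a lower number a stronger inhibitor:
compound 1 `CN(CCCN1C(=O)CSC1c1cc(C(C)(C)C)c(O)c(C(C)(C)C)c1)CC1CC1` gives 1200 nM;
compound 2 `CC(C)(C)c1cc(C2SCC(=O)N2CCCN2CCC(Cc3ccccc3)CC2)cc(C(C)(C)C)c1O` gives 210 nM;
compound 3 `COc1cc2c(cc1OC)CN(CCCN1C(=O)CSC1c1cc(C(C)(C)C)c(O)c(C(C)(C)C)c1)CC2` gives 200 nM.

Compound 1 has the highest number of the three, and its gaps to compound 2 and compound 3 both lie beyond the scatter, so it is the weakest inhibitor here. Compound 4 `CN(CCCN1C(=O)CSC1c1cc(C(C)(C)C)c(O)c(C(C)(C)C)c1)Cc1ccccc1` differs from compound 1 in one place: phenyl in place of cyclopropyl on a saturated chain carbon bound to an amine nitrogen. Among the measured compounds shown here, no measured pair shows this exact change, so the outcome rests on the wider picture, where the two compounds with an aromatic ring in the amine portion sit lower. A moderate drop, beyond the scatter, is expected; the step of a 2.7-fold lower number from compound 1 to compound 4 (0.43 log units; beyond the scatter) is my estimate. Compound 4 is estimated at 450 nM, in the range 150 nM to 1300 nM.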

Compound 4, half-maximal inhibitory concentration: 600 nM
The estimate for compound 4 lay 1.3-fold (0.12 log units) below the measured number; the measured number falls inside the stated range.
By their numbers in this assay, from the lowest: compounds 3 and 2 (each within the scatter of the next); then compounds 4 and 1 (each within the scatter of the next).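

In this assay, phenyl in place of cyclopropyl on a saturated chain carbon bound to an amine nitrogen gives a 2.0-fold lower number from compound 1 to compound 4 (0.30 log units; within the scatter). This first direct comparison at this position shows that the six-membered aromatic ring and the three-membered ring cannot be told apart here, so this swap alone does not clearly change inhibition. No supporting measurement bears on this result. Open, going by these compounds, is whether a cyclohexyl group, a pyridyl ring or a longer chain carrying the phenyl would separate clearly from compound 1 .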